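From methyl to acetyl on a ring nitrogen

The source may report more compounds than this note shows. Statements on the series, on what has been measured and on what is new or still open speak of the compounds shown alone.

Measured so far in an ADME assay on Vero cells (Chlorocebus sabaeus) for cytotoxicity, read by MTT assay; a lower number here means a stronger inhibitor, a higher number a weaker inhibitor:
- compound 1 `O=C(Nc1ccccc1)c1cc(N2CCc3ccccc3C2)ncn1` gives "not determined" (no result reported)
- compound 2 `CN(Cc1ccc(C(F)(F)F)nc1)c1cc(C(=O)Nc2ccccc2)ncn1` gives 258000 nM
- compound 3 `CN1CCN(c2ccc(NC(=O)c3cc(N(C)Cc4ccc(C(F)(F)F)nc4)ncn3)cc2)CC1` gives 45200 nM

Compound 3 holds the lower of the two actual numbers. Next comes compound 4 `CC(=O)N1CCN(c2ccc(NC(=O)c3cc(N(C)Cc4ccc(C(F)(F)F)nc4)ncn3)cc2)CC1`, with acetyl in place of methyl on an amine nitrogen in a ring. Going by the values given here, only one measured step bears on this: a 5.7-fold lower number from compound 2 to compound 3 (0.76 log units; beyond the scatter), which brought in the whole 4-methylpiperazin-1-yl in place of hydrogen on an aromatic carbon. Among the compounds with values here, since the new change keeps that ring, a smaller step than that one is expected, probably towards a higher number in this assay, though no measured pair tests this swap. The expected shift is a 1.5-fold higher number from compound 3 to compound 4 (0.19 log units; within the scatter), possibly within the usual scatter. For compound 4 the estimated value is 70000 nM, with an expected range from 30000 nM to 170000 nM.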

Compound 4, half-maximal inhibitory concentration in the Vero assay: > 50000 nM
Compound 4: only a limit was reported (the forecaster's own chance of this, stated with the estimate: 15%); the middle value is on the limit's open side.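

In the Vero assay, acetyl in place of methyl on this ring nitrogen gives an at least 1.1-fold higher number from compound 3 to compound 4 (0.04 log units; that floor lies within the scatter), which is only a floor, since compound 4 gave a limit there; the step from compound 2 to compound 4 cannot be read. In a physicochemical assay for solubility, using the shake flask method, measured as kinetic solubility, with a stated time of 2 h, at pH 7.4 (on this read-out lower numbers stand for lower solubility and higher numbers for higher solubility), the same change weighs far more, lowering solubility: the measured solubility of compound 3, 165000 nM, and of compound 4, < 5000 nM, an at least 33-fold lower number (1.51 log units; beyond the scatter) In the physicochemical assay compound 3 gives 165000 nM as a measured value. In the physicochemical assay compound 4 gives < 5000 nM and that figure is also a limit.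

As far as these compounds go, the true numbers behind both limits stay open. So does whether a longer chain or a carboxylic acid on this ring nitrogen would track methyl or acetyl.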